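The source may report more compounds than this note shows. Statements on the series, on what has been measured and on what is new or still open speak of the compounds shown alone.

In a functional assay on KB cells (Homo sapiens) for antiproliferative activity, read by MTT assay, with a stated time of 48 h (a lower number here means a stronger inhibitor, a higher number a weaker inhibitor), compound 2 (`Cn1cc(C2=C(c3nn(CCCN4CCCCC4)c4ncccc34)C(=O)N(c3cccc4ccccc34)C2=O)c2ccccc21`) gives 13400 nM and compound 3 (`Cn1cc(C2=C(c3nn(CCCn4ccnc4)c4ncccc34)C(=O)N(c3ccccc3)C2=O)c2ccccc21`) gives 6800 nM as its number, and these two values lie within the usual scatter of each other. Compound 1 (`Cn1cc(C2=C(c3nn(CCCn4cccc4)c4ncccc34)C(=O)NC2=O)c2ccccc21`) returns > 100000 nM in this assay which is a limit and not a number. Compound 2 therefore stands level with compound 3 among the numbers available.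

Compound 4 (`COc1ccc(N2C(=O)C(c3cn(C)c4ccccc34)=C(c3nn(CCCN4CCCCC4)c4ncccc34)C2=O)cc1`) has 4-methoxyphenyl in place of naphthalen-1-yl on an amide-type nitrogen in a ring and is otherwise the same as compound 2. Within the data shown here, no measured pair shows a change at this place, so the data give no direct size for the step. With compound 2 at 13400 nM and compound 3 at 6800 nM within the scatter of each other, no step beyond the scatter is expected in this assay. The estimated change a 1.3-fold lower number from compound 2 to compound 4 (0.13 log units; within the scatter) is expected to stay within that scatter. In this assay the expected value for compound 4 is 10000 nM with a range from 3000 nM to 40000 nM as estimated here.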

Compound 4, half-maximal inhibitory concentration: 44000 nM
The estimate for compound 4 lay 4.4-fold (0.64 log units) below the measured number, outside the stated range (above it).
By their numbers in this assay, from the lowest: compounds 3 and 2 (each within the scatter of the next); then compound 4. At a limit, above all of these: compound 1.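

In this assay, among these compounds, the group on the amide-type nitrogen in the ring is the first place where a single change can be read, and it proves not to be indifferent: 4-methoxyphenyl in place of naphthalen-1-yl gives a 3.3-fold higher number from compound 2 to compound 4 (0.52 log units; beyond the scatter), a modest step but one the earlier compounds, which differ in more than one place, could not show. The change takes away one of the two six-membered aromatic rings and brings in one hydrogen-bond acceptor, and this single step cannot separate those two differences. Nothing measured here bears on the cause of the step.

The compounds shown leave open how an unsubstituted phenyl, a 4-chlorophenyl or a benzyl group would stand on this nitrogen with the rest of compound 2 kept. They also leave open whether the same step would appear with the imidazol-1-yl chain of compound 3 in place of the piperidin-1-yl chain.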